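The compounds below may be only part of what the source reports. "The series", "measured", "known", "first", "only" and "open" are said of these compounds alone.

In an assay on CHO cells for displacement of a labelled ligand from adenosine receptor A3 (Homo sapiens), read by scintillation counting, with a stated time of 3 h (on this read-out lower numbers stand for stronger inhibition and higher numbers for weaker inhibition), compound 2 `CCCn1c(-c2ccccc2)nc2c(NC3CCOC3)ncnc21` gives 2810 nM, the highest number of the three measured compounds. Compound 1 `CCCn1c(-c2ccccc2)nc2c(NC3CCCC3)ncnc21` gives 749 nM, and compound 3 `CCn1c(-c2ccccc2)nc2c(NC3CCOC3)ncnc21` gives 1660 nM. The change from compound 2 to compound 4 `CCCn1c(-c2ccccc2)nc2c(N)ncnc21` is hydrogen in place of oxolan-3-yl on a nitrogen on an aromatic ring. Two measured steps are known. Swapping the ring on that nitrogen gave a 3.8-fold higher number from compound 1 to compound 2 (0.57 log units; beyond the scatter), which shows that what sits on this nitrogen moves the number beyond the scatter. Shortening the chain on the other side gave a 1.7-fold lower number from compound 2 to compound 3 (0.23 log units; within the scatter), which does not touch the nitrogen in question. Among the compounds with values here, neither step removes the ring substituent altogether, so the size of the step in this assay is not fixed by the data; the only step on this nitrogen, that from compound 1 to compound 2, moved the number upward, and a larger loss of the group is expected to move it further upward. For compound 4 the expected value is 10000 nM, with a range from 3000 nM to 40000 nM. That corresponds to an expected step of a 3.6-fold higher number from compound 2 to compound 4 (0.55 log units; beyond the scatter).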

Compound 4, inhibition constant: 9280 nM
Compound 4: middle estimate off by 1.1-fold (0.03 log units), on the high side; the measured number falls inside the stated range.
By their numbers in this assay, from the lowest: compound 1; then compounds 3 and 2 (each within the scatter of the next); then compound 4.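

In this assay, removing the ring from the nitrogen altogether gives a 3.3-fold higher number from compound 2 to compound 4 (0.52 log units; beyond the scatter) and, starting from cyclopentyl, a 12-fold higher number from compound 1 to compound 4 (1.09 log units; beyond the scatter) in the same direction. Within the data shown here, the earlier compounds compared only one ring with another on this nitrogen, whereas these steps show that hydrogen there gives a higher number than either oxolan-3-yl or cyclopentyl, both beyond the scatter. Nothing measured here explains why the number moves this way.

The compounds shown carry only cyclopentyl, oxolan-3-yl and hydrogen on this nitrogen, so it stays open whether a longer open chain, a benzyl group or a ring bearing an amine would give a number lower than that of compound 1. As far as these compounds go, it is also open whether the chain change seen between compound 2 and compound 3 would read the same with hydrogen or cyclopentyl on the nitrogen.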